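This account rests on a few compounds, and the source may have more. Where it says the series, first, only, none or still open, it means among the compounds named here.

Working notes on the series. In a functional assay on A2780 cells (Homo sapiens) for inhibition, read by sulforhodamine B assay, with a stated time of 72 h (a lower number here means a stronger inhibitor, a higher number a weaker inhibitor), compound 1 `Cc1cccc(S(=O)(=O)c2ccc(CNC(=O)c3cc4cnccc4[nH]3)cc2)c1` gives 4 nM, the lowest of the two numbers in hand. Compound 3 `O=C(NCc1ccc(S(=O)(=O)c2ccccc2)cc1)c1ccc2nccn2c1` gives 13 nM in this assay. Compound 2 `O=C(NCc1ccc(S(=O)(=O)c2ccccc2)cc1)c1cn2ccnc2cn1` gives > 10000 nM, which is a limit of the assay and not a number; see (the limit of > 10000 nM in this assay, at which 1 of the 3 values shown sits). Among the measured compounds shown here, the single measured step, an at least 760-fold lower number from compound 2 to compound 3 (2.88 log units; beyond the scatter), concerns the ring on the carbonyl carbon and not the sulfonyl side of the core. Compound 4 `Cc1ccccc1S(=O)(=O)c1ccc(CNC(=O)c2cc3cnccc3[nH]2)cc1` differs from compound 1 by 2-methylphenyl in place of 3-methylphenyl on a sulfonyl sulfur. For the measured compounds named here, no measured step bears on this change, so no size can be read off for it from the series. The step is therefore expected to stay within the usual scatter, a 2.0-fold higher number from compound 1 to compound 4 (0.30 log units; within the scatter). Compound 4 is estimated at 8 nM, between 2 nM and 40 nM.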

Compound 4, half-maximal inhibitory concentration: 13 nM
The estimate for compound 4 lay 1.6-fold (0.21 log units) below the measured number; measured number inside the range.
By their numbers in this assay, from the lowest: compound 1; then compounds 3 and 4 (each within the scatter of the next). At a limit, above all of these: compound 2.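

In this assay the sulfonyl side of the series gets its first measured step, 2-methylphenyl in place of 3-methylphenyl on a sulfonyl sulfur: a 3.3-fold higher number from compound 1 to compound 4 (0.51 log units; beyond the scatter). The two groups have the same atoms, so where the methyl sits on the ring is enough to give a modest step beyond the scatter. Nothing in hand gives a cause for this step. Open, going by these compounds, is how a chlorine, an amine or a carboxylic acid in place of the methyl would read. Also open, on these data alone, is whether this step holds on other groups on the carbonyl carbon.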